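The compounds below may be only part of what the source reports. "The series", "measured", "known", "first", "only" and "open" are said of these compounds alone.

In a functional assay (strain AB) with Danio rerio as the target, read by microscopy, with a stated time of 1 h (a higher number here means that more compound is needed for the effect, a lower number that less compound is needed), compound 1 `CC(C)(C)OC(=O)N1CCc2c(sc(NC(=O)Nc3ccc(Cl)cc3)c2C(N)=O)C1` returns only a limit, > 25000 nM. Where compound 1 stands is thus told solely by the limit of > 25000 nM in this assay, at which 1 of the 2 values shown sits. For the measured compounds named here, compound 2 `CCN1CCc2c(sc(NC(=O)Nc3ccc(Cl)cc3Cl)c2C(N)=O)C1` gives 11500 nM in this assay, the single finite number so far. Compound 3 `CC(C)(C)OC(=O)CCCCN1CCc2c(sc(NC(=O)Nc3ccc(Cl)cc3)c2C(N)=O)C1` differs from compound 1 by 4-(tert-butoxycarbonyl)butyl in place of tert-butoxycarbonyl on an amine nitrogen in a ring. Going by the values given here, no step between measured compounds is available, so the expectation rests on this change alone; a modest gain in potency, about at the edge of the scatter, is expected, an at least 1.6-fold lower number from compound 1 to compound 3 (0.22 log units; that floor lies within the scatter). Compound 3 is therefore estimated at 15000 nM, with a likely range from 5000 nM to 50000 nM.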

Compound 3, half-maximal effective concentration: 710 nM
Compound 3: middle estimate off by 21-fold (1.32 log units), on the high side, outside the stated range (below it).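

Replacing tert-butoxycarbonyl with 4-(tert-butoxycarbonyl)butyl on an amine nitrogen in a ring gives an at least 35-fold lower number from compound 1 to compound 3 (1.54 log units; beyond the scatter) in this assay and shows that this position strongly affects the read-out. Neither group has a ring or a net charge, and both have the same hydrogen-bond acceptor count, so the entering group differs here by its added carbon atoms. This step is only a floor, as compound 1 stands at a limit: the limit of > 25000 nM in this assay, at which 1 of the 3 values shown sits.

From the compounds shown here alone, what remains open is whether the butyl chain or its ester end matters more. A carboxylic acid, an amine or a longer chain in this place would separate the two.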